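This account rests on a few compounds, and the source may have more. Where it says the series, first, only, none or still open, it means among the compounds named here.

Measured values in this series:

Compound 1 `CC(C)C[C@H](NC(=O)OCC1CC2C=CC1C2)C(=O)N[C@H](C=O)C[C@H]1CCNC1=O`: in a functional assay on Huh-7 cells (Homo sapiens) for cytotoxicity (on this read-out lower numbers stand for higher toxicity in this test and higher numbers for lower toxicity in this test), compound 1 gives > 100000 nM, which is a limit of the assay and not a number.
Compound 2 `CC(C)C[C@H](NC(=O)OCC1CC2CCCC(C2)C1)C(=O)N[C@@H](C[C@H]1CCNC1=O)C(O)S(=O)(=O)O`: in this assay compound 2 gives > 100000 nM; > 100000 nM (2 entries), again a limit only.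
Compound 3 `CC(C)C[C@H](NC(=O)OCC1CC2C=CCC(C2)C1)C(=O)N[C@@H](C[C@H]1CCNC1=O)C(O)S(=O)(=O)O`: in this assay compound 3 gives > 100000 nM; > 100000 nM (2 entries), likewise a limit.

For the measured compounds named here, compound 1 therefore stands at the edge of what this test resolves; no single number is available for it, nor for compounds 2 and 3, and no step between measured compounds can be drawn. The only firm point is the limit of > 100000 nM in this assay, at which 1 of the 3 values shown sits.

Compound 4 `CC(C)C[C@H](NC(=O)OCC1CC2C=CC1C2)C(=O)N[C@@H](C[C@H]1CCNC1=O)C(O)S(=O)(=O)O` differs from compound 1 by hydroxy(sulfo)methyl in place of formyl on a saturated chain carbon bound to an amide-type nitrogen and a saturated chain carbon. With compounds 2 and 3, which carry the same entering group, also sitting at the limit, no step beyond the usual scatter is expected for compound 4 in this assay, in either direction. The expected step is a step that the limit leaves unreadable from compound 1 to compound 4. Compound 4 is estimated at 150000 nM, within 100000 nM to 300000 nM, most probably reported again as a limit.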

Compound 4, half-maximal cytotoxic concentration: > 100000 nM
Compound 4 gave a limit, no number (the forecaster's own chance of this, stated with the estimate: 90%); the middle value does not contradict the limit.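

Compound 1 and compound 4 both give only a limit in this assay, not a number, so no step can be read between them. The compounds shown leave open whether hydroxy(sulfo)methyl in place of formyl changes the half-maximal cytotoxic concentration at all.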